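From Trifluoromethyl to Methyl on the Shared Core

The source may hold more compounds than are shown below. What is called first, only, known or untested is meant among the compounds shown, and "the series" means these compounds.

Three compounds have been measured in a functional assay on MCF7 cells (Homo sapiens) for antiproliferative activity, read by MTT assay, with a stated time of 48 h; a higher number here means a weaker inhibitor, a lower number a stronger inhibitor:
Compound 1 `COc1ccc(-c2nn(-c3ccccc3)cc2-c2nc3cc(Cl)ccc3[nH]2)cc1` gives 1760 nM
Compound 2 `COc1ccc(-c2nn(-c3ccccc3)cc2-c2nc3cc(Br)ccc3[nH]2)cc1` gives 1830 nM
Compound 3 `COc1ccc(-c2nn(-c3ccccc3)cc2-c2nc3cc(C(F)(F)F)ccc3[nH]2)cc1` gives 5730 nM

Compound 3 has the highest of the three numbers and is the weakest of them. The chloro and bromo compounds cannot be told apart, with a 1.0-fold higher number from compound 1 to compound 2 (0.02 log units; within the scatter) as the step between them. Compound 4 (`COc1ccc(-c2nn(-c3ccccc3)cc2-c2nc3cc(C)ccc3[nH]2)cc1`) keeps the shared core and differs from compound 3 in a single group, methyl in place of trifluoromethyl on an aromatic carbon.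

Within the data shown here, no measured step involves methyl, so the evidence is indirect. The nearest guides are the two modest steps that bring in trifluoromethyl at this place, a 3.3-fold higher number from compound 1 to compound 3 (0.51 log units; beyond the scatter) and a 3.1-fold higher number from compound 2 to compound 3 (0.50 log units; beyond the scatter) in this assay as the measured cases. Removing trifluoromethyl is therefore expected to lower the number, although the data do not show whether methyl would match chloro and bromo. The expected move is a 2.2-fold lower number from compound 3 to compound 4 (0.34 log units; beyond the scatter) and would be a modest one. For compound 4 the estimated value is 2600 nM with an expected range from 1200 nM to 6000 nM in this measurement.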

Compound 4, half-maximal inhibitory concentration: 6610 nM
Compound 4: the middle estimate sits 2.5-fold (0.41 log units) below what was measured; measured number above the stated range.
By their numbers in this assay, from the lowest: compounds 1 and 2 (each within the scatter of the next); then compounds 3 and 4 (each within the scatter of the next).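

In this assay, the change at this aromatic carbon gives a 1.2-fold higher number from compound 3 to compound 4 (0.06 log units; within the scatter) even though a single carbon replaces the 4 heavy atoms of trifluoromethyl, so methyl and trifluoromethyl cannot be told apart at this position. Methyl instead falls on the same side as trifluoromethyl relative to the halogens, with a 3.6-fold higher number from compound 2 to compound 4 (0.56 log units; beyond the scatter) and a 3.8-fold higher number from compound 1 to compound 4 (0.57 log units; beyond the scatter) as its modest steps, so among these four compounds the gap at this position runs between chloro and bromo on one side and methyl and trifluoromethyl on the other, and it is not peculiar to trifluoromethyl. Nothing available here offers any explanation for this grouping.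

The compounds shown leave open where other groups at this place would fall, such as fluoro, an amine, a hydroxyl or a carboxylic acid, and thus whether the division seen here extends beyond these four substituents. They also leave open whether the same grouping would hold on a core other than the shared one, or in any setting other than this assay.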